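Swapping Nitro for Trifluoromethyl in a Dioxygenase Inhibitor Series

A few compounds are considered here, and "the series" means these few. Any claim that something is new, unique, unknown or untested is made for them only; others in the source may bear on it.

In an assay for inhibition of Tryptophan 2,3-dioxygenase (Homo sapiens), with stated times of 10 min and 60 min, tested at 10 uM (on this read-out higher numbers stand for a stronger effect at the one concentration tested and lower numbers for a weaker effect), three compounds have so far been measured:

Compound 1 `O=[N+]([O-])c1ccccc1CNc1cc(Br)cc2cn[nH]c12`: 35%
Compound 2 `O=[N+]([O-])c1cccc(CNc2cc(C(F)(F)F)cc3[nH]ncc23)c1`: 60%
Compound 3 `O=C1NC(=O)c2c(NCc3ccccc3[N+](=O)[O-])cccc21`: 17%

Compound 2 stands highest of these three numbers. Compound 1 lies nearest to it, yet its number in this assay is lower by more than the usual scatter, and compound 3 lies furthest, again beyond the scatter. Since no two of the measured compounds differ in only one place, none of these gaps can be tied to a single structural change.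

The next compound, compound 4 `FC(F)(F)c1cccc(CNc2cc(C(F)(F)F)cc3[nH]ncc23)c1`, is built from compound 2 by one change, (trifluoromethyl in place of nitro on an aromatic carbon). Going by the values given here, the nitro group that leaves carries two hydrogen-bond acceptors and the trifluoromethyl that enters carries none, but nothing among the measured compounds shows what this exchange does in this assay. The expectation is therefore a modest step, a number 10 percentage points lower from compound 2 to compound 4 (within the scatter), more likely downward than upward, and possibly none beyond the scatter. On that basis compound 4 is expected to give about 50% in this assay, with a range from 25% to 72%.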

Compound 4, a percentage reported as inhibition, at one concentration (the size of the read-out at that concentration, not a potency): 40%
Compound 4: middle estimate off by 10 percentage points, on the high side; the range from low to high includes it.
By their numbers in this assay, from the lowest: compound 3; then compounds 1 and 4 (each within the scatter of the next); then compound 2.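

In this assay, going by these compounds alone, the exchange of nitro for trifluoromethyl on this aromatic carbon gives a number 20 percentage points lower from compound 2 to compound 4 (beyond the scatter) and this is the first comparison that can be tied to a single structural change. It shows that the group at this place has a bearing on the read-out: with the rest of the molecule unchanged, the nitro group with its two hydrogen-bond acceptors gives way to a trifluoromethyl group with none, and the number moves by more than the usual scatter. Nothing available explains why the number falls, and the difference in acceptor count remains a description of the two groups, not an established cause.

The compounds shown leave open how an amine, a nitrile or a carboxylic acid at this place would compare with nitro and trifluoromethyl, and so whether hydrogen-bond acceptors have anything to do with this step. They also leave open whether the same exchange would move the number in the same direction, and by a similar amount, on the core of compound 1 or of compound 3.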